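Anilide aryl substituent: compound 4 against compounds 1 to 3

A few compounds are considered here, and "the series" means these few. Any claim that something is new, unique, unknown or untested is made for them only; others in the source may bear on it.

Compound 1 `Cc1ccccc1NC(=O)CCC(=O)OCCCCCCSc1ccc([N+](=O)[O-])c2nonc12` gives 4020 nM in a functional assay on HOS cells (Homo sapiens) for inhibition, read by MTT assay, with a stated time of 72 h; a lower number here means a stronger inhibitor, a higher number a weaker inhibitor.
Compound 2 `O=C(CCC(=O)OCCCCCCSc1ccc([N+](=O)[O-])c2nonc12)Nc1ccc(F)cc1` gives 2080 nM in this assay.
Compound 3 `Cc1ccc(NC(=O)CCC(=O)OCCCCCCSc2ccc([N+](=O)[O-])c3nonc23)cc1` gives 3340 nM in this assay.

Compound 3 stands second highest of the three numbers; compound 1 is nearest, a 1.2-fold lower number from compound 1 to compound 3 (0.08 log units; within the scatter), and compound 2 furthest, a 1.6-fold higher number from compound 2 to compound 3 (0.21 log units; within the scatter). Compound 4 `COc1ccc(NC(=O)CCC(=O)OCCCCCCSc2ccc([N+](=O)[O-])c3nonc23)cc1` differs from compound 3 by methoxy in place of methyl on an aromatic carbon. For the measured compounds named here, no measured step exchanges methyl for methoxy. Going by the values given here, the steps that bear on it are the other exchanges of the aryl group on the amide-type nitrogen: a 1.9-fold lower number from compound 1 to compound 2 (0.29 log units; within the scatter), a 1.2-fold lower number from compound 1 to compound 3 (0.08 log units; within the scatter) and a 1.6-fold higher number from compound 2 to compound 3 (0.21 log units; within the scatter), each within the scatter. A step of that size in this assay is therefore expected, none beyond the scatter, in either direction, giving a 1.1-fold lower number from compound 3 to compound 4 (0.05 log units; within the scatter). Compound 4 is estimated at 3000 nM, with a range of 1500 nM to 6000 nM.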

Compound 4, half-maximal inhibitory concentration: 1800 nM
For compound 4 the middle estimate is 1.7-fold (0.22 log units) above the measured one, and the stated range covers the measured number.
By their numbers in this assay, from the lowest: compounds 4, 2, 3 and 1 (each within the scatter of the next, the first and the last beyond it).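

Methoxy at this place on the ring, para to a large group, stays within the scatter of both methyl (a 1.9-fold lower number from compound 3 to compound 4 (0.27 log units; within the scatter)) and fluoro (a 1.2-fold lower number from compound 2 to compound 4 (0.06 log units; within the scatter)) in this assay. For the compounds shown here, the 4-methoxyphenyl group in place of 2-methylphenyl gives the first step in the set beyond the scatter, though a modest one (a 2.2-fold lower number from compound 1 to compound 4 (0.35 log units; beyond the scatter)). No measurement at hand accounts for these steps.

From the compounds shown here alone, what an amine or a carboxylic acid at this place on the ring would give remains open. So does the effect of a longer chain linking the ester to the core.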